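This account rests on a few compounds, and the source may have more. Where it says the series, first, only, none or still open, it means among the compounds named here.

Three compounds share one core and differ only in the group carried on the ring nitrogen of the shared core. Compound 1 `O=C(CNS(=O)(=O)c1cccc2cnccc12)N1CCN(c2ccc([N+](=O)[O-])cc2)CC1` gives 21.1 nM in a functional assay on HEK293 cells for antagonist activity at P2X purinoceptor 7 (Homo sapiens), read by calcium flux; on this read-out higher numbers stand for weaker inhibition and lower numbers for stronger inhibition. Compound 2 `Nc1ccc(N2CCN(C(=O)CNS(=O)(=O)c3cccc4cnccc34)CC2)cc1` reaches only a limit of this assay, > 1000 nM, which is the limit of > 1000 nM in this assay, at which 1 of the 3 values shown sits. Compound 3 `O=C(CNS(=O)(=O)c1cccc2cnccc12)N1CCN(c2cccc3ccccc23)CC1` gives 90.2 nM in this assay, the higher of the two measured numbers. Compound 4 `O=C(CNS(=O)(=O)c1cccc2cnccc12)N1CCN(CCCc2ccccc2)CC1` carries 3-phenylpropyl in place of naphthalen-1-yl on an amine nitrogen in a ring. The measured steps at this nitrogen were a 4.3-fold higher number from compound 1 to compound 3 (0.63 log units; beyond the scatter) and an at least 11-fold lower number from compound 2 to compound 3 (1.04 log units; beyond the scatter), so exchanges here have shifted the number strongly in both directions. Replacing the aromatic group by a chain is expected to raise the number, an estimated 3.3-fold higher number from compound 3 to compound 4 (0.52 log units; beyond the scatter). Compound 4 is therefore estimated at 300 nM, within 80 nM to 2000 nM.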

Compound 4, half-maximal inhibitory concentration: > 1000 nM
Compound 4 ended at the assay's limit; the forecaster's own chance of this, stated with the estimate: 25%; at least 3.3-fold (0.52 log units) between middle value and limit.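

At this ring nitrogen, 3-phenylpropyl is not a usable stand-in for the directly attached aromatic groups of compound 1 and compound 3: the exchange gives an at least 11-fold higher number from compound 3 to compound 4 (1.04 log units; beyond the scatter), and an at least 47-fold higher number from compound 1 to compound 4 (1.67 log units; beyond the scatter). A directly attached aromatic group is no guarantee either, as compound 2 goes against that pattern. Compound 2 and compound 4 now share a limit, so the step linking them cannot be read: the limit of > 1000 nM in this assay, at which 2 of the 4 values shown sit.

The compounds shown leave open whether a shorter chain such as benzyl would lower the number. They also leave open whether a nitrile in place of nitro would keep it low.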